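The source may hold more compounds than are shown below. What is called first, only, known or untested is meant among the compounds shown, and "the series" means these compounds.

The set rests on a single number. Among the compounds with values here, compound 1 (`CCOc1cc(CNC(=O)c2ncoc2-c2ccc(OC)cc2)cc(OCC)c1OCC`) is the only member with a result in an assay on tissue (HeLa cells) for inhibition of Indoleamine 2,3-dioxygenase 1 (Homo sapiens), read by spectrophotometry, with a stated time of 48 h (a higher number here means a weaker inhibitor, a lower number a stronger inhibitor), where compound 1 gives 6.3 nM. Compound 2 (`COc1ccc(-c2cn(CCNc3nonc3/C(=N/O)Nc3ccc(F)c(Br)c3)nn2)cc1`) belongs to a different shared core, and in this assay compound 2 is entered as "not determined" (no result reported), with no result reported. Compound 3 (`OCCCc1cn(CCNc2nonc2/C(=N/O)Nc2ccc(F)c(Br)c2)nn1`) shares that second core with compound 2, and in this assay compound 3 is likewise entered as "not determined" (no result reported), with no number reported; it therefore stands nowhere on the measured scale, and compound 1 cannot serve as a reference for it, since the two cores differ throughout.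

Compound 4 (`OCCOCc1cn(CCNc2nonc2/C(=N/O)Nc2ccc(F)c(Br)c2)nn1`) is the next member of the second core. It differs from compound 3 in one place: 2-hydroxyethoxy in place of 2-hydroxyethyl on a saturated chain carbon bound to an aromatic carbon. Within the data shown here, no step between measured compounds of this core exists, so the size and direction of this change in this assay cannot be read from the data; a step no larger than the usual scatter seems the most likely outcome, in either direction.

With no anchor on this core, any number for compound 4 is a guess. Compound 4 is expected to give about 60 nM in this assay, within a wide range from 5 nM to 800 nM.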

Compound 4, half-maximal inhibitory concentration: 2.16 nM
For compound 4 the middle estimate is 28-fold (1.44 log units) above the measured one, outside the stated range (below it).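

Compound 4 gives 2.16 nM in this assay, while compound 3 has no single number there, and no step can be read between compound 3 and compound 4. The compounds shown leave open what replacing 2-hydroxyethyl with 2-hydroxyethoxy does on this shared core. Nothing shown bears on the cause of this result.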